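The source may report more compounds than this note shows. Statements on the series, on what has been measured and on what is new or still open speak of the compounds shown alone.

Measured so far in a functional assay on KBVIN cells (Homo sapiens) for antiproliferative activity, read by sulforhodamine B assay, with a stated time of 3 days; a higher number here means that more compound is needed for the effect, a lower number that less compound is needed:
compound 1 `CCOc1ccc(-c2cc(=O)c3c(o2)C(CC)(CC)C(=O)C(CC)=C3O)cc1`: 7.54 uM
compound 2 `CCCOc1ccc(-c2cc(=O)c3c(o2)C(CC)(CC)C(=O)C(CC)=C3O)cc1`: 29.2 uM

Compound 2 stands at the higher end of the two, at 29.2 uM. Compound 3 `CCC1=C(O)c2c(oc(-c3ccc(SC)cc3)cc2=O)C(CC)(CC)C1=O` is next, with the change methylsulfanyl in place of propoxy on an aromatic carbon, para to a large group.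

Among the compounds with values here, one measured step bears on this, a 3.9-fold higher number from compound 1 to compound 2 (0.59 log units; beyond the scatter), which is modest and beyond the scatter. Within the data shown here, its bearing is partial: it extends the chain on the oxygen, and no compound with methylsulfanyl has been measured. Shortening the group from propoxy may therefore reverse part of that step, so a lower number is expected in this assay. The expected change is a 2.7-fold lower number from compound 2 to compound 3 (0.42 log units; beyond the scatter), somewhat smaller than the measured step. For compound 3 the estimated value is 11 uM, with an expected range of 4 uM to 30 uM.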

Compound 3, concentration for half-maximal effect: 1.38 uM
Estimate against measurement, compound 3: 8.0-fold (0.90 log units) above; measured number below the stated range.
By their numbers in this assay, from the lowest: compound 3; then compound 1; then compound 2.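

In this assay, the position para to a large group proves more sensitive than the ether chain step alone suggested, with a 21-fold lower number from compound 2 to compound 3 (1.33 log units; beyond the scatter) and with a 5.5-fold lower number from compound 1 to compound 3 (0.74 log units; beyond the scatter) as well. Methylsulfanyl therefore does more than recover the ethoxy level, and among the three compounds the number falls as the group goes from propoxy to ethoxy to methylsulfanyl. No measurement here gives a reason for the size of this drop.

The change to methylsulfanyl alters the atom on the ring and shortens the group together, so the compounds shown do not separate the two. Methoxy would test the shorter chain with oxygen retained, and ethylsulfanyl would test whether a longer chain on sulfur raises the number as it does on oxygen.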